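The compounds below may be only part of what the source reports. "The series", "measured", "known", "first", "only" and "open" are said of these compounds alone.

Measured compounds in a functional assay on U-251 cells (Homo sapiens) for inhibition, read by sulforhodamine B assay, with a stated time of 48 h; on this read-out lower numbers stand for stronger inhibition of growth and higher numbers for weaker inhibition of growth:
- compound 1, `COc1cc(/C=C/C2CC=CC(=O)O2)cc(OC)c1OC`, gives 25.1 uM
- compound 2, `O=C1C=CCC(/C=C/c2ccccc2)N1`, gives 798 uM
- compound 3, `O=C1C=CCC(/C=C/c2ccc(C(F)(F)F)cc2)N1`, gives 130 uM

Compound 3 stands second highest of the three numbers in this assay. Compound 1 is nearest to it, with a lower number, and compound 2 is furthest, with a higher number. For the measured compounds named here, the one single-point step that is known, a 6.1-fold lower number from compound 2 to compound 3 (0.79 log units; beyond the scatter), is a modest one and involves trifluoromethyl in place of hydrogen on an aromatic carbon.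

Compound 4, `COc1ccc(/C=C/C2CC=CC(=O)N2)cc1`, is not yet measured. It differs from compound 3 in one place: methoxy in place of trifluoromethyl on an aromatic carbon

Going by the values given here, no measured pair shows methoxy in place of trifluoromethyl, so the step cannot be read off directly. What is known is that compound 2, lacking the trifluoromethyl, gives a higher number than compound 3 in this assay, and compound 1, which carries methoxy groups on a different core, gives a lower number than compound 3. Compound 4 is therefore expected to land between compound 2 and compound 3, that is a somewhat higher number than compound 3, with the step of a 1.9-fold higher number from compound 3 to compound 4 (0.28 log units; within the scatter) expected to be modest. The estimate for compound 4 in this assay is 250 uM, within a range of 80 uM to 700 uM.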

Compound 4, concentration for growth inhibition (reported as GI): 981 uM
Compound 4: the middle estimate sits 3.9-fold (0.59 log units) below what was measured; the measured number lies above the stated range.
By their numbers in this assay, from the lowest: compound 1; then compound 3; then compounds 2 and 4 (each within the scatter of the next).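

In this assay, the place on an aromatic carbon of the six-membered aromatic ring, para to a group of 9 heavy atoms, proves sensitive to which group sits there, and not merely to whether hydrogen is replaced: methoxy in place of trifluoromethyl gives a 7.5-fold higher number from compound 3 to compound 4 (0.88 log units; beyond the scatter), which removes the whole advantage that compound 3 held. Methoxy in place of hydrogen gives a 1.2-fold higher number from compound 2 to compound 4 (0.09 log units; within the scatter), so methoxy and hydrogen cannot be told apart here, and among these three groups only trifluoromethyl stands apart, with compound 3 separated beyond the scatter from both compound 2 and compound 4. No measurement at hand speaks to the reason for this difference between the groups.

The compounds shown leave open whether another group at this place, such as a nitrile, an amine or a carboxylic acid, would side with trifluoromethyl or with hydrogen and methoxy. They also leave open how the lower number of compound 1 relates to this series, since compound 1 differs from compound 4 in more than one place and no single change can be read from that pair.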